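This account rests on a few compounds, and the source may have more. Where it says the series, first, only, none or still open, it means among the compounds named here.

Of the compounds shown here, three built on one shared core have been tested in an ADME assay on HEK293 cells for agonist activity at metabotropic glutamate receptor 5 (Rattus norvegicus), read by fluorescence and calcium flux; a lower number here means a smaller maximal response, a higher number a larger maximal response. Compound 1, `C[C@@H](NC(=O)c1ccc(C#Cc2ccccc2)cn1)C(C)(C)O`, gives 43.2%. Compound 2, `C[C@@H](NC(=O)c1ccc(C#CC2CCCC2)cn1)C(C)(C)O`, gives 14.8%. Compound 3, `C[C@@H](NC(=O)c1ccc(C#Cc2cccc(F)n2)cn1)C(C)(C)O`, gives 8.3%, the lowest of the three numbers, though its gap to compound 2 lies within the scatter, while compound 1 stands well above it. Two steps lead toward compound 3: a number 28.4 percentage points lower from compound 1 to compound 2 (beyond the scatter), and a number 34.9 percentage points lower from compound 1 to compound 3 (beyond the scatter). The remaining pairing, a number 6.5 percentage points lower from compound 2 to compound 3 (within the scatter), shows nothing beyond the scatter.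

Compound 4, `C[C@@H](NC(=O)c1ccc(C#Cc2ccc(F)cn2)cn1)C(C)(C)O`, differs from compound 3 in one place: 5-fluoropyridin-2-yl in place of 6-fluoropyridin-2-yl on a triple-bonded carbon. The two compounds hold the same atoms, joined differently. Among the compounds with values here, none of the measured steps exchanges one fluoropyridinyl group for another, so no step speaks directly to this change. The nearest guide is that compound 3 and compound 2 already sit within the scatter of each other, both far below compound 1, so the region around compound 3 has so far shown little movement. The expectation is therefore a step no larger than the scatter, a number 3.7 percentage points higher from compound 3 to compound 4 (within the scatter). Compound 4 is estimated at 12%, with a likely range from 3% to 30%.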

Compound 4, largest response reached (reported as efficacy), in percent of the reference or control that the assay uses: 13.5%
Compound 4: the middle estimate sits 1.5 percentage points below what was measured; the range from low to high includes it.
By their numbers in this assay, from the lowest: compounds 3, 4 and 2 (each within the scatter of the next); then compound 1.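

In this assay, 5-fluoropyridin-2-yl in place of 6-fluoropyridin-2-yl on the triple-bonded carbon gives a number 5.2 percentage points higher from compound 3 to compound 4 (within the scatter), the first direct test of exchanging one fluoropyridinyl group for another, and this exchange shows no effect beyond the scatter. The other two steps place the new group alongside the earlier ones: a number 1.3 percentage points lower from compound 2 to compound 4 (within the scatter) leaves it level with the cyclopentyl group, while a number 29.7 percentage points lower from compound 1 to compound 4 (beyond the scatter) sets it clearly apart from the phenyl group, so among these four compounds only the phenyl compound stands apart, and none goes against this. No measurement here offers an explanation for these results.

Going by these compounds, what remains open is whether the gap to the phenyl compound goes with the ring nitrogen, with the fluorine or with both, a question that a plain pyridin-2-yl group, carrying no fluorine, could help to separate. On these data alone, it is also open whether a chlorine or a nitrile in the place of the fluorine would stay as close to compound 3 and compound 4 in this read-out.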